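The source may hold more compounds than are shown below. What is called first, only, known or untested is meant among the compounds shown, and "the series" means these compounds.

Measured in a functional assay on the whole organism with Rattus norvegicus as the target; a higher number here means that more compound is needed for the effect, a lower number that less compound is needed:
- compound 1 `CCOC(=O)C(=O)Nc1nc(-c2cc(C)no2)cs1`: 0.2 mg/kg
- compound 2 `COc1cc(-c2csc(NC(=O)C(=O)O)n2)on1`: 1.2 mg/kg

Compound 2 has the higher number of the two, and compound 1 lies below it by more than the scatter. Compound 3 `Cc1cc(-c2csc(NC(=O)C(=O)O)n2)on1` is still to be measured in this assay. It has methyl in place of methoxy on an aromatic carbon of compound 2: methyl in place of methoxy on an aromatic carbon. Going by the values given here, no measured pair shows the size of this change, so the expectation is loose, and no step beyond the scatter is expected. The estimated step is a 1.2-fold lower number from compound 2 to compound 3 (0.08 log units; within the scatter). The expected value for compound 3 is 1 mg/kg, with an estimated range of 0.3 mg/kg to 3.5 mg/kg.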

Compound 3, dose for half-maximal effect: 0.3 mg/kg
Estimate against measurement, compound 3: 3.3-fold (0.52 log units) above; low and high end bracket the measured number.
By their numbers in this assay, from the lowest: compounds 1 and 3 (each within the scatter of the next); then compound 2.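

In this assay, the group on this aromatic carbon next to the ring nitrogen matters: methyl in place of methoxy gives a 4.0-fold lower number from compound 2 to compound 3 (0.60 log units; beyond the scatter) on the shared core. With methyl on that carbon, hydrogen in place of ethyl on the oxygen next to a carbonyl group gives a 1.5-fold higher number from compound 1 to compound 3 (0.18 log units; within the scatter) and so does not separate the two compounds. No measurement at hand accounts for the methoxy-to-methyl step.

From the compounds shown here alone, whether an ethyl group, a chlorine or an amine on that carbon would match methyl remains open. Also open, going by these compounds, is whether ethyl on the oxygen changes the number when methoxy occupies the ring carbon.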